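Flipping One Ring Centre in a Weak Hemolysis Inhibitor

The source may report more compounds than this note shows. Statements on the series, on what has been measured and on what is new or still open speak of the compounds shown alone.

Compound 2, `COc1ccc(C(=O)O)c2c1C[C@](C)(C1CC=C(C)CC1)O2`, gives 680000 nM in a functional assay on the whole organism for inhibition, with Homo sapiens as the target, read by hemolysis; on this read-out lower numbers stand for stronger inhibition and higher numbers for weaker inhibition.
Compound 1, `CC1=CCC([C@]2(C)Cc3c(O)ccc(C(=O)O)c3O2)CC1`, gives 2400000 nM in this assay.

Of these two numbers, compound 2 gives the lower one; compound 1 stands higher by a gap beyond the usual scatter. Compound 3, `COc1ccc(C(=O)O)c2c1C[C@@](C)(C1CC=C(C)CC1)O2`, keeps every atom and bond of compound 2 and differs only in this: the two compounds have the same atoms and bonds; at least one stereo element is drawn with a configuration in one of them and without one in the other: 1 of 2 stereo elements differ; a stereocentre at a saturated ring carbon is drawn R in compound 2 and S in compound 3. Among the compounds with values here, no measured pair shows what such an inversion does here, so the expectation rests on the unchanged skeleton alone: a change no larger than the scatter, or a modest weakening. Compound 3 is expected to give about 1000000 nM, within 350000 nM to 3000000 nM. The expected step is a 1.5-fold higher number from compound 2 to compound 3 (0.17 log units; within the scatter).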

Compound 3, half-maximal inhibitory concentration: 380000 nM
Compound 3: middle estimate off by 2.6-fold (0.42 log units), on the high side; the measured number falls inside the stated range.
By their numbers in this assay, from the lowest: compounds 3 and 2 (each within the scatter of the next); then compound 1.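

In this assay this ring centre can be inverted with little consequence: the swap gives a 1.8-fold lower number from compound 2 to compound 3 (0.25 log units; within the scatter) and so moves the number no further than repeat measurements would. Methyl in place of hydrogen on an oxygen on an aromatic ring gives a 6.3-fold lower number from compound 1 to compound 3 (0.80 log units; beyond the scatter) and is the only one of these two steps that clears the scatter. One caution applies to the inversion step: the fact that one of compounds 2 and 3 is drawn with a defined configuration and the other without, at the place where they differ

As far as these compounds go, what an ethyl group or a longer chain on that oxygen would do remains open, as does the effect of an amide in place of the carboxylic acid.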